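The compounds below may be only part of what the source reports. "The series", "measured", "known", "first", "only" and "open" are said of these compounds alone.

Of the compounds shown here, three have so far been measured in a functional assay on MIA PaCa-2 cells (Homo sapiens) for antiproliferative activity, read by sulforhodamine B assay, with a stated time of 48 h; a lower number here means a stronger inhibitor, a higher number a weaker inhibitor. Compound 2 `COc1ccc2nc(-c3ccc(N/C=C\C(=O)c4ccc(OC)c(F)c4)cc3)sc2c1` gives 1300 nM, the lowest of the three numbers. Compound 3 `COc1cc(OC)c2sc(-c3ccc(N/C=C\C(=O)c4ccc(OC)c(F)c4)cc3)nc2c1` gives 4300 nM, and compound 1 `COc1ccc2nc(-c3ccc(N/C=C\C(=O)c4ccc(OC)c(O)c4)c(C)c3)sc2c1` gives 17000 nM; both gaps to compound 2 lie beyond the scatter. A fourth compound, compound 4 `COc1ccc2nc(-c3ccc(N/C=C\C(=O)c4ccc(OC)c(O)c4)cc3)sc2c1`, has not yet been measured. It differs from compound 2 in one place: hydroxy in place of fluoro on an aromatic carbon. For the measured compounds named here, no pair of measured compounds differs by exactly this change, so the step has to be expected rather than read off. Going by the values given here, the only measured compound carrying the hydroxy group, compound 1, gives 17000 nM, a weak value. On that basis the step is expected to be a weakening, estimated as a 3.1-fold higher number from compound 2 to compound 4 (0.49 log units; beyond the scatter). Compound 4 is therefore expected to give about 4000 nM, within a range from 1500 nM to 12000 nM.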

Compound 4, half-maximal inhibitory concentration: 21900 nM
Compound 4: middle estimate off by 5.5-fold (0.74 log units), on the low side; measured number above the stated range.
By their numbers in this assay, from the lowest: compound 2; then compound 3; then compounds 1 and 4 (each within the scatter of the next).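

In this assay, the change from 3-fluoro-4-methoxyphenyl to 3-hydroxy-4-methoxyphenyl can now be read directly, and a 17-fold higher number from compound 2 to compound 4 (1.23 log units; beyond the scatter) marks it as a large loss of potency. The methyl group of compound 1 makes no readable difference, with a 1.3-fold higher number from compound 1 to compound 4 (0.11 log units; within the scatter) as the step on removing it, so that methyl does not account for the weak value of compound 1. Nothing measured here explains the loss. As far as these compounds go, whether a chloro group or an amine at this position would match or beat fluoro remains open.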